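This account rests on a few compounds, and the source may have more. Where it says the series, first, only, none or still open, it means among the compounds named here.

In a functional assay on PC-3 cells (Homo sapiens) for antiproliferative activity, read by MTT assay, with a stated time of 48 h (on this read-out lower numbers stand for stronger inhibition and higher numbers for weaker inhibition), compound 1 `Cc1nnc(Sc2cc(NC(=O)c3ccc(Cl)cc3)c3ccccc3c2O)s1` gives 49500 nM. Compound 2 `O=C(Nc1cc(Sc2ncn[nH]2)c(O)c2ccccc12)c1ccc2ccccc2c1` reaches only a limit of this assay, > 100000 nM, so its place among the numbers is known only as a bound, as noted for (the limit of > 100000 nM in this assay, at which 1 of the 2 values shown sits). Compound 3 `Cc1cccc(C(=O)Nc2cc(Sc3ncn[nH]3)c(O)c3ccccc23)c1` differs from compound 2 in one place: 3-methylphenyl in place of naphthalen-2-yl on a carbonyl carbon. Going by the values given here, no measured pair shows this kind of change. A step of an at least 1.6-fold lower number from compound 2 to compound 3 (0.22 log units; that floor lies within the scatter) is expected, toward stronger inhibition but scarcely beyond the usual scatter. This expectation rests on compound 1, whose single aromatic ring gives 49500 nM. Compound 3 is therefore estimated at 60000 nM, within 20000 nM to 200000 nM.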

Compound 3, half-maximal inhibitory concentration: 59500 nM
Compound 3: the middle estimate sits 1.0-fold (0.00 log units) above what was measured; measured number inside the range.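

Going by these compounds alone, putting 3-methylphenyl in place of naphthalen-2-yl on the carbonyl carbon gives the first step at this position in this assay: an at least 1.6-fold lower number from compound 2 to compound 3 (0.22 log units; that floor lies within the scatter). With one aromatic ring of carbon only in place of two, compound 3 gives a measured number, 59500 nM. The true size of the step stays unknown because the value of compound 2 is a limit and only a floor can be read: the limit of > 100000 nM in this assay, at which 1 of the 3 values shown sits.

Going by these compounds, whether an amine, a carboxylic acid or a longer chain on this carbonyl carbon would change the number remains open.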